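The compounds below may be only part of what the source reports. "The series", "measured", "known", "first", "only" and "open" are said of these compounds alone.

Of the compounds shown here, three built on one shared core have so far been measured in an assay on cells for activation of probable G-protein coupled receptor 34 (Mus musculus), with a stated time of 1 h; on this read-out lower numbers stand for smaller maximal responses and higher numbers for larger maximal responses. Compound 1 `N[C@@H](COP(=O)(O)OCCCOC(=O)CCc1ccccc1OCc1cccc(Cc2ccccc2)c1)C(=O)O` gives 0.077, the lowest of the three numbers. Compound 2 `Cc1cccc(Oc2cccc(COc3ccccc3CCC(=O)OCCCOP(=O)(O)OC[C@H](N)C(=O)O)c2)c1` gives 0.29, and compound 3 `N[C@@H](COP(=O)(O)OCCCOC(=O)CCc1ccccc1OCc1cccc(Oc2ccc(Cl)cc2)c1)C(=O)O` gives 0.76. Both changes away from compound 1 raised the response: a number 0.21 higher from compound 1 to compound 2 (beyond the scatter) and a number 0.68 higher from compound 1 to compound 3 (beyond the scatter). Between the two phenoxy compounds themselves, a number 0.47 higher from compound 2 to compound 3 (beyond the scatter).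

Compound 4 `CCc1ccc(Oc2cccc(COc3ccccc3CCC(=O)OCCCOP(=O)(O)OC[C@H](N)C(=O)O)c2)cc1` has not yet been measured. It differs from compound 1 in one place: 4-ethylphenoxy in place of benzyl on an aromatic carbon. Like compounds 2 and 3, it trades the benzyl for a phenoxy group, and the entering 4-ethylphenoxy resembles the 4-chlorophenoxy of compound 3 more closely than the 3-methylphenoxy of compound 2. Both measured steps from compound 1 point upward and lie beyond the scatter, so a rise beyond the scatter is expected here too. Because compound 3 reached 0.76 while compound 2 reached 0.29, the step expected for compound 4 is a number 0.52 higher from compound 1 to compound 4 (beyond the scatter). Compound 4 is therefore estimated at 0.6, with a range from 0.35 to 0.85.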

Compound 4, intrinsic activity: the largest response reached, as a fraction of the reference agonist's: 0.42
The estimate for compound 4 lay 0.18 above the measured number, within the range that was stated.
By their numbers in this assay, from the lowest: compound 1; then compound 2; then compound 4; then compound 3.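

In this assay, a third phenoxy group again outperforms the benzyl of the core, with a number 0.34 higher from compound 1 to compound 4 (beyond the scatter), so all three phenoxy compounds shown lie above compound 1. The group on the far ring also matters, not just the switch to phenoxy: with a number 0.34 lower from compound 3 to compound 4 (beyond the scatter), exchanging chloro for ethyl at the same place removes about half of the gain seen with compound 3. The smaller difference, a number 0.13 higher from compound 2 to compound 4 (beyond the scatter), changes both the group and its place on that ring, so these two effects cannot be separated here.

The data shown offer no explanation for the gap between chloro and ethyl. Also open, on these data alone, is the response with an amine, a methoxy group or a longer carbon chain in place of the ethyl of compound 4.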